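Thiophene-fused cores and cytotoxicity: a sulfanyl variant awaits

A few compounds are considered here, and "the series" means these few. Any claim that something is new, unique, unknown or untested is made for them only; others in the source may bear on it.

Compound 1 `COc1ccc(-c2nc(COc3cccc(Cl)c3)nc3ccsc23)cn1` in an ADME assay on cells (Homo sapiens) for cytotoxicity, read by resazurin assay, with a stated time of 5 days (on this read-out lower numbers stand for higher toxicity in this test and higher numbers for lower toxicity in this test), gives > 50000 nM, a limit of the assay.
Compound 2 `COc1ccc(-c2nc(CSc3cc(C)cc(C)c3)nc3ccsc23)cn1` in this assay gives > 50000 nM, a limit of the assay.
Compound 3 `COc1ccc(-c2nc(CCc3cccc(Cl)c3)nc3ccsc23)cn1` in this assay gives > 50000 nM, a limit of the assay.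

Compound 3 stands where the other two stand: all three values are limits rather than numbers, and the limit of > 50000 nM in this assay, at which 3 of the 3 values shown sit, makes that plain. The steps among them cannot be read: a step that the two limits leave unreadable from compound 1 to compound 2, a step that the two limits leave unreadable from compound 1 to compound 3 and a step that the two limits leave unreadable from compound 2 to compound 3 are all hidden by the limits on both sides.

Compound 4 `COc1ccc(-c2nc(CSc3cccc(Cl)c3)nc3ccsc23)cn1` has not yet been tested in this assay. It differs from compound 3 in one place: (3-chlorophenyl)sulfanyl in place of 3-chlorobenzyl on a saturated chain carbon bound to an aromatic carbon. The same kind of change, a sulfanyl-linked aryl group instead of an oxygen- or carbon-linked one, occurs among the measured compounds, but each of those steps sits between two limits and shows no size. Within the data shown here, there is therefore no measured step that points to a shift of any size in this assay for compound 4, and the expectation rests on all three values being limits. Compound 4 is estimated to give 60000 nM, within 30000 nM to 150000 nM, so the step that the limit leaves unreadable from compound 3 to compound 4 is expected to be none beyond the scatter, most likely reported again only as a limit.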

Compound 4, half-maximal cytotoxic concentration: > 10000 nM
Compound 4 was reported as a limit; the forecaster's own chance of this, stated with the estimate: 85%; the middle value is on the limit's open side.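

In this assay compound 4 gives > 10000 nM, a limit of the assay. The steps from compound 4 to compound 1, compound 2 and compound 3 cannot be read, with limits on both sides. The compounds shown leave open at what concentration, if any, these four compounds would register as toxic in this assay, and whether exchanging the groups on the saturated chain carbon changes that.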